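From thiophen-3-yl to 1-benzofuran-2-yl: an expected step

The source may hold more compounds than are shown below. What is called first, only, known or untested is meant among the compounds shown, and "the series" means these compounds.

Measured in a functional assay on K562 cells (Homo sapiens), read by MTT assay, with a stated time of 72 h (a higher number here means a weaker inhibitor, a lower number a stronger inhibitor), with the two limits marked:
- compound 1 `Cc1ncnc2c1c(-c1ccoc1)cn2[C@@H]1O[C@H](CO)[C@@H](O)[C@H]1O` gives > 20000 nM (a limit)
- compound 2 `Cc1ncnc2c1c(-c1cccs1)cn2[C@@H]1O[C@H](CO)[C@@H](O)[C@H]1O` gives > 20000 nM (a limit)
- compound 3 `Cc1ncnc2c1c(-c1ccsc1)cn2[C@@H]1O[C@H](CO)[C@@H](O)[C@H]1O` gives 5550 nM (a number)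

Compound 3 alone has a true number. The other two values are limits, as the limit of > 20000 nM in this assay, at which 2 of the 3 values shown sit, makes plain.

Compound 4 `Cc1ncnc2c1c(-c1cc3ccccc3o1)cn2[C@@H]1O[C@H](CO)[C@@H](O)[C@H]1O` has not been measured. It carries 1-benzofuran-2-yl in place of thiophen-3-yl on an aromatic carbon of the shared core: 1-benzofuran-2-yl in place of thiophen-3-yl on an aromatic carbon.

Among the measured compounds shown here, two measured steps bear on this swap, and both end at thiophen-3-yl. One is an at least 3.6-fold lower number from compound 1 to compound 3 (0.55 log units; beyond the scatter), and the other is an at least 3.6-fold lower number from compound 2 to compound 3 (0.55 log units; beyond the scatter). Each is beyond the scatter, so in these three compounds replacing thiophen-3-yl with another single ring leaves only a limit. Neither step tests a group with two rings, so carrying this over to compound 4 is uncertain, but a higher number is expected.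

The expected change is a 2.5-fold higher number from compound 3 to compound 4 (0.40 log units; beyond the scatter), toward a weaker inhibitor. For compound 4 the estimated value is 14000 nM, with an expected range of 4000 nM to 40000 nM.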

Compound 4, half-maximal inhibitory concentration: > 20000 nM
Compound 4 was reported as a limit (the forecaster's own chance of this, stated with the estimate: 55%); middle value at least 1.4-fold (0.15 log units) away from the limit.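

In this assay the change from one ring to two gives an at least 3.6-fold higher number from compound 3 to compound 4 (0.55 log units; beyond the scatter) and so extends what the single-ring groups showed: 1-benzofuran-2-yl also fails to match thiophen-3-yl at this position, even though it keeps a five-membered aromatic ring with one hetero atom. The steps to compound 4 from compound 1 and from compound 2 join limit to limit and cannot be read. Compound 4 gives > 20000 nM, which is a limit and not a number, and this same limit now covers most of the compounds shown: the limit of > 20000 nM in this assay, at which 3 of the 4 values shown sit.

Thiophen-3-yl therefore remains the only group here with a true number, so no trend in ring size can be drawn. Going by these compounds, it remains open whether a six-membered ring such as phenyl, or a thiophen-3-yl ring carrying an amine or a carboxylic acid, would give a number at this position.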